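Aryl variation on the amide-type nitrogen: compound 3

The compounds below may be only part of what the source reports. "The series", "measured", "known", "first", "only" and "open" are said of these compounds alone.

Of the compounds shown here, two have numbers so far. Compound 2 `COc1cccc(NC(=O)Nc2cc(C(C)(C)C)nn2-c2ccccc2)c1` and compound 1 `CC(C)(C)c1cc(NC(=O)Nc2ccc(F)c(F)c2)n(-c2ccccc2)n1` are both read in an assay on isolated protein for inhibition of Ephrin type-A receptor 2 (Homo sapiens), read by thermal shift assay, tested at 10 uM; a higher number here means that the compound stabilises the target more against heat, a lower number that the compound stabilises the target less; compound 2 gives 1.8 degrees C and compound 1 gives 2.2 degrees C, and these two numbers lie within the scatter of each other, so neither compound stands apart from the other. Compound 3 `Cc1ccc(NC(=O)Nc2cc(C(C)(C)C)nn2-c2ccccc2)cc1` is not yet measured. It differs from compound 2 in one place: 4-methylphenyl in place of 3-methoxyphenyl on an amide-type nitrogen. Within the data shown here, the only measured step that bears on this kind of change is a number 0.40 degrees C lower from compound 1 to compound 2 (within the scatter), itself an exchange of one substituted phenyl for another at the same place, and it did not move the number beyond the scatter. Among the measured compounds shown here, no measured step concerns a methyl in place of a methoxy, so the expectation rests on that single step alone. On that basis the step from compound 2 to compound 3 is expected to be small, no change at the digits printed from compound 2 to compound 3 (within the scatter), with no direction beyond the scatter. Compound 3 is therefore estimated at 1.8 degrees C in this assay, within a range of 0.8 degrees C to 2.8 degrees C.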

Compound 3, shift of the target's melting temperature: 1.7 degrees C
Compound 3: middle estimate off by 0.10 degrees C, on the high side, within the range that was stated.
By their numbers in this assay, from the lowest: compounds 3, 2 and 1 (each within the scatter of the next).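

Replacing 3-methoxyphenyl, with 1 hydrogen-bond acceptor, by 4-methylphenyl, with 0, on the amide-type nitrogen reads in this assay as a number 0.10 degrees C lower from compound 2 to compound 3 (within the scatter) and so removes the acceptor of this group without a step beyond the scatter. The remaining comparison at this place, a number 0.50 degrees C lower from compound 1 to compound 3 (within the scatter) for 4-methylphenyl in place of 3,4-difluorophenyl, completes the set: all three substituted phenyl groups shown lie within the scatter of one another, and no exchange among them separates the compounds. Nothing shown offers an explanation for the size of these steps.

The compounds shown leave open whether this position stays as flat once the group on the amide-type nitrogen is more than a phenyl with small substituents, for example a phenyl bearing a carboxylic acid or an amine, or a longer alkyl chain in place of the aromatic ring. They also leave open whether any exchange at this place can lift the thermal shift beyond the scatter, since the shared core is the same throughout and only this one position has been varied among the compounds in view.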